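The compounds below may be only part of what the source reports. "The series", "measured", "known", "first", "only" and "open" are said of these compounds alone.

Among the measured compounds shown here, in a functional assay on PC-3 cells (Homo sapiens) for antiproliferative activity, read by MTT assay, with a stated time of 72 h (on this read-out higher numbers stand for weaker inhibition and lower numbers for stronger inhibition), compound 1 `O=C(N/N=C/c1ccc(Br)cc1)Nc1ccc(Oc2ccnc3[nH]ccc23)c(F)c1` gives 920 nM and compound 2 `O=C(N/N=C/c1ccc([N+](=O)[O-])cc1)Nc1ccc(Oc2ccnc3[nH]ccc23)c(F)c1` gives 150 nM, the lower of the two numbers measured so far. Compound 3 `O=C(N/N=C/c1ccc(Cl)c(Cl)c1)Nc1ccc(Oc2ccnc3[nH]ccc23)c(F)c1` differs from compound 2 by 3,4-dichlorophenyl in place of 4-nitrophenyl on a carbon with a double bond to nitrogen. For the measured compounds named here, only one measured step bears on this change: a 6.1-fold lower number from compound 1 to compound 2 (0.79 log units; beyond the scatter), a modest step that came with nitro in place of bromo on an aromatic carbon. Compound 3, like compound 1, carries no nitro group, so a move back towards a higher number is expected in this assay, although a single step is thin support. The expected change is a 3.2-fold higher number from compound 2 to compound 3 (0.51 log units; beyond the scatter). For compound 3 the estimated value is 480 nM, with an expected range from 150 nM to 1500 nM.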

Compound 3, half-maximal inhibitory concentration: 14100 nM
The estimate for compound 3 lay 29-fold (1.47 log units) below the measured number; the whole stated range lies below it.
By their numbers in this assay, from the lowest: compound 2; then compound 1; then compound 3.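

In this assay, the group on a carbon with a double bond to nitrogen proves able to move the number much further than the first pair suggested, with a 94-fold higher number from compound 2 to compound 3 (1.97 log units; beyond the scatter) standing as the largest change among the three compounds. Losing 4-nitrophenyl does not account for this alone: compound 1 also has no nitro group, yet 3,4-dichlorophenyl in place of 4-bromophenyl gives a 15-fold higher number from compound 1 to compound 3 (1.19 log units; beyond the scatter), so among these compounds a halogen-bearing ring does not by itself fix the number. No information is available on why these groups differ so sharply.

The compounds shown leave open whether the rise from compound 1 to compound 3 goes with the second chlorine or with chlorine replacing bromine. They also leave open how 4-chlorophenyl, or a ring bearing an amine or methoxy group, would stand at this position.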